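Nitro for hydroxy on the aryl amine of the series

This account rests on a few compounds, and the source may have more. Where it says the series, first, only, none or still open, it means among the compounds named here.

Measured so far:
compound 1 `COc1ccc(Nc2cncc(N3CC4CC(C3)N4)c2)cc1` — 2.2 nM
compound 2 `Oc1ccc(Nc2cncc(N3CC4CC(C3)N4)c2)cc1` — 0.988 nM

Going by the values given here, compound 2 holds the lowest of the two numbers in an assay on HEK293 cells for displacement of a labelled ligand from Neuronal acetylcholine receptor; alpha3/beta4 (Homo sapiens); a lower number here means a stronger inhibitor, a higher number a weaker inhibitor; its nearest neighbour is compound 1, and the change a 2.2-fold lower number from compound 1 to compound 2 (0.35 log units; beyond the scatter) is the only step so far that is beyond the scatter.

Compound 3 `O=[N+]([O-])c1ccc(Nc2cncc(N3CC4CC(C3)N4)c2)cc1` is not yet measured. It differs from compound 2 by nitro in place of hydroxy on an aromatic carbon, the change sitting on an aromatic carbon of a six-membered aromatic ring of carbon only, para to a large group. Among the compounds with values here, no measured step replaces the hydroxy group with anything other than the methoxy of compound 1; the one step of a 2.2-fold lower number from compound 1 to compound 2 (0.35 log units; beyond the scatter) bears on this position only in that it shows the substituent there is read by this assay, and modestly so. A change of this size in the same position is therefore expected to move the number by a small amount at most, with the direction uncertain and a weakening somewhat more likely than none.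

Compound 3 is estimated at 2.5 nM, with a range of 0.8 nM to 8 nM. This corresponds to an expected step of a 2.5-fold higher number from compound 2 to compound 3 (0.40 log units; beyond the scatter).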

Compound 3, inhibition constant: 0.684 nM
Compound 3: middle estimate off by 3.7-fold (0.56 log units), on the high side; the whole stated range lies above it.
By their numbers in this assay, from the lowest: compounds 3 and 2 (each within the scatter of the next); then compound 1.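

In this assay the replacement of hydroxy by nitro reads as a 1.4-fold lower number from compound 2 to compound 3 (0.16 log units; within the scatter) and so gives no separation between these two groups, even though nitro brings three heavy atoms and no hydrogen-bond donor where hydroxy had one heavy atom and one hydrogen-bond donor. Among the compounds shown, a hydrogen-bond donor on this aromatic carbon is therefore not needed for a value in this low range. The comparison of nitro with methoxy gives a 3.2-fold lower number from compound 1 to compound 3 (0.51 log units; beyond the scatter) and is modest, so the position does distinguish between some of its groups, but all three compounds sit in a narrow band, and no measurement at hand explains the order.

Still open, from the compounds shown here alone, is whether an amine, a carboxylic acid or a longer chain such as an alkoxy group on the same carbon would stay in that band or leave it. Also open, going by these compounds, is whether nitro would read the same way elsewhere on the ring, and whether the band holds for any receptor other than the one in this assay.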